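A few compounds are considered here, and "the series" means these few. Any claim that something is new, unique, unknown or untested is made for them only; others in the source may bear on it.

Measured in a functional assay on L6 cells (Rattus norvegicus) for cytotoxicity; a lower number here means a stronger inhibitor, a higher number a weaker inhibitor:
- Compound 1 `N=C(N)c1ccc(-c2ccc(-c3ccc(C(=N)N)cn3)cc2)nc1`: 26600 nM
- Compound 2 `N=C(N)c1ccc(-c2ccc(-c3ccc(C(=N)N)cc3)c(F)c2)cc1`: 6400 nM
- Compound 3 `N=C(NO)c1ccc(-c2ccc(-c3ccc(/C(N)=N\O)cc3)cc2)cc1`: > 211000 nM (a limit of the assay, not a number)

Only two of these results are actual numbers. Compound 2, at 6400 nM, has the lower of them, and the gap between it and compound 1, at 26600 nM, lies beyond the usual scatter. The reading for compound 3 is a limit, > 211000 nM.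

The next compound, compound 4 `N=C(N)c1ccc(-c2ccc(-c3ccc(C(=N)N)cc3)c(C(F)(F)F)c2)cc1`, keeps the frame of compound 2 but carries trifluoromethyl in place of fluoro on an aromatic carbon. Going by the values given here, no two measured compounds differ in one place only, so the data give no direct size for this kind of change. With no such guide, the expectation in this assay is for no change beyond the scatter, with a slight lean towards a higher number. The expected step is a 1.3-fold higher number from compound 2 to compound 4 (0.10 log units; within the scatter). For compound 4 the estimated value is 8000 nM, with an expected range of 2500 nM to 25000 nM.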

Compound 4, half-maximal inhibitory concentration: 9400 nM
The estimate for compound 4 lay 1.2-fold (0.07 log units) below the measured number; the range from low to high includes it.
By their numbers in this assay, from the lowest: compounds 2 and 4 (each within the scatter of the next); then compound 1. At a limit, above all of these: compound 3.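

In this assay, trifluoromethyl in place of fluoro on this aromatic carbon gives a 1.5-fold higher number from compound 2 to compound 4 (0.17 log units; within the scatter), so a group of 4 heavy atoms can replace a group of 1 here without a shift that stands out from the scatter. This is the first pair among the compounds shown that differ in one place, and so the first direct reading of any change on this scaffold in this assay. Nothing measured here speaks to why the two compounds read alike.

Going by these compounds, both groups at this position contain fluorine, so it remains open whether an amine or a carboxylic acid on the same aromatic carbon would also stay within the scatter of compound 2. Also open, on these data alone, is how plain hydrogen at this position would compare with fluoro and trifluoromethyl.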